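Swapping Trifluoromethyl for Cyclopropyloxy on a Stable Core

The source may report more compounds than this note shows. Statements on the series, on what has been measured and on what is new or still open speak of the compounds shown alone.

Compound 1 `O=C(O)CCCSc1nnc(-c2ccc(Cl)cc2Cl)o1` and compound 2 `O=C(O)CCCSc1nnc(-c2ccc(C(F)(F)F)cc2Cl)o1` share one core and differ in a single group on the aromatic ring. In an ADME assay on microsomes from liver (Mus musculus, strain CD-1) for metabolic stability, read by LC-MS, using NADPH, tested at 1 uM (on this read-out lower numbers stand for a shorter-lived compound and higher numbers for a longer-lived compound), compound 1 reaches > 1 h, which is a limit of the measurement rather than a number. Compound 2 likewise reaches > 1 h in this assay, again a limit. The step that the two limits leave unreadable from compound 1 to compound 2 is therefore unreadable. Compound 3 `O=C(O)CCCSc1nnc(-c2ccc(OC3CC3)cc2Cl)o1` differs from compound 2 in that (cyclopropyloxy in place of trifluoromethyl on an aromatic carbon). Among the compounds with values here, no measured step bears on this change; the only evidence is the limit of > 1 h in this assay, at which 2 of the 2 values shown sit. Compound 3 is expected to give about 1.5 h, in a range from 0.7 h to 3 h. The expected step that the limit leaves unreadable from compound 2 to compound 3 is none beyond the scatter.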

Compound 3, half-life: > 1 h
Compound 3 gave a limit, no number (the forecaster's own chance of this, stated with the estimate: 65%); the middle value lies beyond the limit too.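

Compound 3 also gives only a limit, so no step among compound 1, compound 2 and compound 3 can be read: the limit of > 1 h in this assay, at which 3 of the 3 values shown sit.

From the compounds shown here alone, the actual half-lives, and whether chloro, trifluoromethyl and cyclopropyloxy differ at all in their effect on them, remain open.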